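Chloro for hydroxy on the aryl ketone ring

This account rests on a few compounds, and the source may have more. Where it says the series, first, only, none or still open, it means among the compounds named here.

In a functional assay on SK-MEL-28 cells (Homo sapiens) for cytotoxicity, read by sulforhodamine B assay, with a stated time of 24 h (on this read-out lower numbers stand for stronger inhibition of growth and higher numbers for weaker inhibition of growth), compound 2 `O=C(/C=C/c1cc2ccccc2[nH]c1=O)c1ccc(O)cc1` gives 19500 nM. Compound 1 `COc1ccc(C(=O)/C=C/c2cc3ccccc3[nH]c2=O)cc1` gives 30600 nM in this assay, and the two lie within the scatter of each other, as a 1.6-fold lower number from compound 1 to compound 2 (0.20 log units; within the scatter) shows. Compound 3 `O=C(/C=C/c1cc2ccccc2[nH]c1=O)c1ccc(Cl)cc1` differs from compound 2 by chloro in place of hydroxy on an aromatic carbon. Among the compounds with values here, the one measured step, a 1.6-fold lower number from compound 1 to compound 2 (0.20 log units; within the scatter), concerns the same hydroxy group but only its methylation, not its replacement, so it bears on this change loosely at best; no movement beyond the scatter is expected in this assay. Compound 3 is estimated at 20000 nM, range 8000 nM to 50000 nM. That expectation amounts to a 1.0-fold higher number from compound 2 to compound 3 (0.01 log units; within the scatter).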

Compound 3, concentration for total growth inhibition: 72500 nM
The estimate for compound 3 lay 3.6-fold (0.56 log units) below the measured number, outside the stated range (above it).
By their numbers in this assay, from the lowest: compounds 2 and 1 (each within the scatter of the next); then compound 3.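

In this assay, this position proves sensitive to the group it carries: hydroxy and methoxy lie within the scatter of each other, whereas chloro brings a 3.7-fold higher number from compound 2 to compound 3 (0.57 log units; beyond the scatter) and a 2.4-fold higher number from compound 1 to compound 3 (0.37 log units; beyond the scatter) towards weaker inhibition of growth. The earlier pair could not show this, since it changed only the methylation of the oxygen. Nothing at hand explains the shift. Still open, going by these compounds, is whether the weakening belongs to chloro itself or to the loss of an oxygen-linked group. An amine or a fluoro group at this position could help separate the two.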